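This account rests on a few compounds, and the source may have more. Where it says the series, first, only, none or still open, it means among the compounds named here.

Within the data shown here, in a functional assay on WM 266-4 cells (Homo sapiens) for antiproliferative activity, read by MTT assay, with a stated time of 24 h (a higher number here means a weaker inhibitor of growth, a lower number a stronger inhibitor of growth), compound 1 `Ic1ccc(C2CC(c3ccc4c(c3)OCCO4)=NN2c2ccccc2)cc1` gives 3470 nM, the middle of the three numbers measured so far. Compound 2 `c1ccc(COc2cccc(C3CC(c4ccc5c(c4)OCCO5)=NN3c3ccccc3)c2)cc1` stands lower at 870 nM, and compound 3 `Fc1ccccc1C1CC(c2ccc3c(c2)OCCO3)=NN1c1ccccc1` stands higher at 9120 nM.

The change under consideration leads to compound 4 `Cc1ccc(C2CC(c3ccc4c(c3)OCCO4)=NN2c2ccccc2)cc1`: methyl in place of iodo on an aromatic carbon. In words, this is methyl in place of iodo on an aromatic carbon, para to a large group, or 4-iodophenyl to 4-methylphenyl.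

Among the measured compounds shown here, no measured compound carries this methyl group, so the data offer no direct comparison. For the measured compounds named here, the only measured step that also removes the 4-iodophenyl group is a 2.6-fold higher number from compound 1 to compound 3 (0.42 log units; beyond the scatter). It is a modest step, and it puts a 2-fluorophenyl group in place of the 4-iodophenyl group, so it is only a loose guide here. Going by the values given here, compound 2 has a different group again and shows only that a lower number is possible.

Going by compound 3 at 9120 nM, the direction expected in this assay is towards a slightly higher number, with a step smaller than that one and probably none beyond the scatter. The estimated step is a 1.3-fold higher number from compound 1 to compound 4 (0.11 log units; within the scatter). For compound 4 the expected value is 4500 nM, with an estimated range of 1800 nM to 11000 nM.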

Compound 4, concentration for 50% growth inhibition: 2530 nM
For compound 4 the middle estimate is 1.8-fold (0.25 log units) above the measured one, within the range that was stated.
By their numbers in this assay, from the lowest: compound 2; then compounds 4 and 1 (each within the scatter of the next); then compound 3.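

In this assay, among these compounds, the first direct reading at this place, on an aromatic carbon para to a large group, is a 1.4-fold lower number from compound 1 to compound 4 (0.14 log units; within the scatter) for methyl in place of iodo, so the two groups cannot be told apart here and the iodine atom is not needed to hold the number at this level. The 4-methylphenyl compound also separates from the 2-fluorophenyl one, with a 3.6-fold lower number from compound 3 to compound 4 (0.56 log units; beyond the scatter) as a modest step beyond the scatter, so both compound 1 and compound 4 now stand clear of compound 3, though that step changes both the group and where it sits. No measurement of any property of these groups accompanies the result, and the data offer no account of why iodo and methyl read alike.

Iodo and methyl are the only two groups seen at this place, so how a methoxy group, an amine or a carboxylic acid would read there remains open. Also open, from the compounds shown here alone, is whether a fluoro group at this same place would match methyl and iodo, which would show whether compound 3 stands apart for its group or for where that group sits.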